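Swapping an Azide for an Aminomethyl Group

A few compounds are considered here, and "the series" means these few. Any claim that something is new, unique, unknown or untested is made for them only; others in the source may bear on it.

The compounds here share one core and differ only in the group attached to a single aromatic carbon of that core. Compound 1 `[N-]=[N+]=Nc1c(F)c(N)c2c(=O)cc(-c3ccc(N)c(F)c3)oc2c1F` carries an azido group at that place. Among the compounds with values here, in a functional assay on MCF7 cells (Homo sapiens) for cytotoxicity, read by neutral red uptake, with a stated time of 3 days (on this read-out higher numbers stand for weaker inhibition and lower numbers for stronger inhibition), compound 1 gives 460 nM, which is the only plain number in this set. Compound 2 `CCCCCCCCCCCCCCCCCC(=O)OCc1c(F)c(N)c2c(=O)cc(-c3ccc(N)c(F)c3)oc2c1F` carries a long ester chain instead. In this assay compound 2 reaches only a limit of the assay, > 10000 nM, so no number is known for it. The evidence the limit of > 10000 nM in this assay, at which 1 of the 2 values shown sits, shows how many of the two values sit at that limit. Between compound 1 and compound 2 one value is a number and one is a limit, and nothing more can be read from them.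

Compound 3 `NCc1c(F)c(N)c2c(=O)cc(-c3ccc(N)c(F)c3)oc2c1F` has not yet been measured. It differs from compound 1 in this way: aminomethyl in place of azido on an aromatic carbon. With only compound 1 as a numbered anchor, the size of the step cannot be read from any measured pair, and a modest weakening is expected, a 3.3-fold higher number from compound 1 to compound 3 (0.51 log units; beyond the scatter). Compound 3 is therefore estimated at 1500 nM, with a range from 300 nM to 8000 nM.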

Compound 3, half-maximal inhibitory concentration: 26 nM
The estimate for compound 3 lay 58-fold (1.76 log units) above the measured number; measured number below the stated range.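

Replacing azido with aminomethyl on this aromatic carbon, ortho to two fluoro groups, gives an 18-fold lower number from compound 1 to compound 3 (1.25 log units; beyond the scatter) in this assay, and on this read-out a lower number stands for stronger inhibition. This is the only pair shown with two plain numbers, so it puts a size on a change at this place for the first time and shows that the group here can strongly shift the result while the rest of the molecule stays the same. The swap brings in a group with 1 hydrogen-bond donor in place of one with 0, but this single pair cannot separate that difference from the others between the two groups, and nothing measured here accounts for the size of the step.

Within the data shown here, compound 2 stands at a limit of the assay, > 10000 nM, so no step involving it can be read. From the compounds shown here alone, it remains open whether a plain amine, a hydroxymethyl group or a longer aminoethyl chain on this carbon would match, exceed or lose the result seen with aminomethyl.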